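The source may report more compounds than this note shows. Statements on the series, on what has been measured and on what is new or still open speak of the compounds shown alone.

Measured so far in a functional assay on MCF7 cells (Homo sapiens) for cytotoxicity, read by MTT assay, with a stated time of 72 h; a higher number here means a weaker inhibitor, a lower number a stronger inhibitor:

Compound 1, `Cc1nnc(SCc2cc(=O)c3cc(Cl)ccc3o2)o1`, gives > 25000 nM, which is a limit of this assay rather than a number.
Compound 2, `Nc1nnc(SCc2cc(=O)c3cc(Cl)ccc3o2)s1`, gives > 25000 nM, again a limit and not a number.
Compound 3, `Cc1nnc(SCc2coc3ccccc3c2=O)o1`, gives 4600 nM.

Two of the three results sit at the same limit, (the limit of > 25000 nM in this assay, at which 2 of the 3 values shown sit), so the step that the two limits leave unreadable from compound 1 to compound 2 cannot be read for size; the change behind it is 5-amino-1,3,4-thiadiazol-2-yl in place of 5-methyl-1,3,4-oxadiazol-2-yl on a sulfur. Going by the values given here, compound 3 is the only compound of the three with a number. The difference between the core of compound 1 and the core of compound 3 is not broken down here.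

Compound 4, `Nc1nnc(SCc2coc3ccccc3c2=O)s1`, is not yet measured. It arises from compound 3 by the same kind of change, (5-amino-1,3,4-thiadiazol-2-yl in place of 5-methyl-1,3,4-oxadiazol-2-yl on a sulfur), with the place line worded identically in both pairs. Among the compounds with values here, the only precedent for this change, from compound 1 to compound 2, gives no readable size, so nothing fixes the direction. The expected step is a 1.3-fold higher number from compound 3 to compound 4 (0.12 log units; within the scatter), treated as flat and resting on the value of compound 3, 4600 nM, alone. The estimate for compound 4 in this assay is therefore 6000 nM, within a wide range from 1800 nM to 25000 nM.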

Compound 4, half-maximal inhibitory concentration: > 25000 nM
Compound 4 ended at the assay's limit (the forecaster's own chance of this, stated with the estimate: 30%); middle value at least 4.1-fold (0.61 log units) from the limit.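

In this assay, placing 5-amino-1,3,4-thiadiazol-2-yl in place of 5-methyl-1,3,4-oxadiazol-2-yl on a sulfur of the core of compound 3 gives an at least 5.4-fold higher number from compound 3 to compound 4 (0.73 log units; beyond the scatter). Compound 4 gives > 25000 nM, which is a limit of the assay and not a number, so the step has a lower bound but no known full size. On the core of compound 1 the same change cannot be read, so the notes show a clear loss on one core but cannot say whether the change carries over with a similar size, and the comparison stops at the limit: the limit of > 25000 nM in this assay, at which 3 of the 4 values shown sit.

Open, on these data alone, is which part of the change carries the step on the core of compound 3, the ring atoms or the amine, and 5-methyl-1,3,4-thiadiazol-2-yl or 5-amino-1,3,4-oxadiazol-2-yl on the same sulfur would separate the two. Also open, as far as these compounds go, is whether any group on that sulfur brings the core of compound 1 to a readable number.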